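Two Methyls on the Sulfonyl Aryl: Expectation for Compound 4

A few compounds are considered here, and "the series" means these few. Any claim that something is new, unique, unknown or untested is made for them only; others in the source may bear on it.

In an assay on isolated protein for displacement of a labelled ligand from metabotropic glutamate receptor 5 (Homo sapiens), with a stated time of 60 min, tested at 1 uM (a higher number here means more inhibition at the concentration tested (going by the name of the read-out), a lower number less inhibition), the three measured compounds gave:
compound 1 `COc1ccc2ncc(S(=O)(=O)c3cccc(F)c3)c(N3CCC(C)CC3)c2c1`: 68%
compound 2 `COc1ccc2ncc(S(=O)(=O)c3ccc(C)cc3)c(N3CCC(C)CC3)c2c1`: 90%
compound 3 `COc1ccc2ncc(S(=O)(=O)c3ccc(F)cc3)c(N3CCC(C)CC3)c2c1`: 27%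

Compound 3 stands lowest of these three numbers, both steps to it lying beyond the scatter: a number 41 percentage points lower from compound 1 to compound 3 (beyond the scatter) and a number 63 percentage points lower from compound 2 to compound 3 (beyond the scatter). Compound 4 `COc1ccc2ncc(S(=O)(=O)c3cc(C)cc(C)c3)c(N3CCC(C)CC3)c2c1` is not yet measured; it differs from compound 3 by 3,5-dimethylphenyl in place of 4-fluorophenyl on a sulfonyl sulfur. For the measured compounds named here, two measured steps bear on this change. The step of a number 63 percentage points lower from compound 2 to compound 3 (beyond the scatter) shows how much fluoro and methyl on the aromatic carbon differ, and the step of a number 41 percentage points lower from compound 1 to compound 3 (beyond the scatter) shows that moving fluoro away from its place in compound 3 also raises the number. A large rise is therefore expected in this assay, a number 48 percentage points higher from compound 3 to compound 4 (beyond the scatter). Compound 4 is estimated at 75%, within a range of 45% to 95%.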

Compound 4, a percentage reported as inhibition, at one concentration (the size of the read-out at that concentration, not a potency): 79%
For compound 4 the middle estimate is 4 percentage points below the measured one; the range from low to high includes it.
By their numbers in this assay, from the lowest: compound 3; then compound 1; then compound 4; then compound 2.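

In this assay, the methyl-bearing aryl groups on the sulfonyl sulfur now both stand above the fluoro-bearing ones, with 3,5-dimethylphenyl clearing 4-fluorophenyl (a number 52 percentage points higher from compound 3 to compound 4 (beyond the scatter)) and 3-fluorophenyl (a number 11 percentage points higher from compound 1 to compound 4 (beyond the scatter)). It does not, however, surpass 4-methylphenyl (a number 11 percentage points lower from compound 2 to compound 4 (beyond the scatter)), so a group without a methyl at the place held in compound 2 can still give a high number. No measurement here accounts for these differences.

As far as these compounds go, what an amine, a carboxylic acid or a longer chain such as propyl would do on this aryl ring stays open, as does 3-methylphenyl.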